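The source may report more compounds than this note shows. Statements on the series, on what has been measured and on what is new or still open speak of the compounds shown alone.

Compound 1 `COc1cccc(OC)c1C(=O)Nc1c[nH]nc1C(=O)NC1CCCCCC1`: 42000 nM
Compound 2 `COCCNC(=O)c1n[nH]cc1NC(=O)c1c(OC)cccc1OC`: > 50000 nM
Compound 3 `COc1cccc(OC)c1C(=O)Nc1c[nH]nc1C(=O)N[C@H]1CC[C@H](OC)CC1`: 31000 nM

In an ADME assay on MRC5 cells (Homo sapiens) for inhibition, with a stated time of 72 h (a lower number here means that less compound is needed, a higher number that more compound is needed for the effect), compound 1 gives 42000 nM and compound 3 gives 31000 nM. Compound 2 reaches only a limit of the assay, > 50000 nM. Compound 3 therefore stands with compound 1, the two numbers lying within the scatter of each other: a 1.4-fold lower number from compound 1 to compound 3 (0.13 log units; within the scatter). Compound 4 `COc1cccc(OC)c1C(=O)Nc1c[nH]nc1C(=O)NN1CCOCC1` is not yet measured and differs from compound 3 in one place: morpholin-4-yl in place of 4-methoxycyclohexyl on an amide-type nitrogen. Two measured steps alter the group on an amide-type nitrogen: an at least 1.6-fold lower number from compound 2 to compound 3 (0.20 log units; that floor lies within the scatter) and a 1.4-fold lower number from compound 1 to compound 3 (0.13 log units; within the scatter). Neither moves the number beyond the scatter, so no shift beyond the scatter is expected for compound 4 either, while one measured value sits at the limit of > 50000 nM in this assay, at which 1 of the 3 values shown sits. Compound 4 is expected to give 40000 nM, between 15000 nM and 60000 nM, an expected step of a 1.3-fold higher number from compound 3 to compound 4 (0.11 log units; within the scatter).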

Compound 4, half-maximal effective concentration: > 50000 nM
Compound 4 ended at the assay's limit (the forecaster's own chance of this, stated with the estimate: 40%); middle value at least 1.2-fold (0.09 log units) from the limit.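

With morpholin-4-yl on the amide-type nitrogen, a ring carrying hetero atoms now joins the open 2-methoxyethyl chain at the limit of this assay: the limit of > 50000 nM in this assay, at which 2 of the 4 values shown sit.

So far, only the rings of carbon, cycloheptyl and 4-methoxycyclohexyl, give readable numbers. Still, an at least 1.6-fold higher number from compound 3 to compound 4 (0.20 log units; that floor lies within the scatter) and an at least 1.1-fold higher number from compound 1 to compound 4 (0.07 log units; that floor lies within the scatter) are only floors, and the step between the two limits cannot be read.

As far as these compounds go, how far past the limit compound 2 and compound 4 lie stays open. So does whether piperidin-1-yl, the same ring without its oxygen, or a longer chain would give a readable number.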